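Aryl thioether imidazolines: carboxy in place of isopropyl

This account rests on a few compounds, and the source may have more. Where it says the series, first, only, none or still open, it means among the compounds named here.

Two compounds of the series have numbers. In an assay (Rattus norvegicus) for binding affinity to prostacyclin receptor (Homo sapiens), read by radioligand binding (a higher number here means a weaker inhibitor, a lower number a stronger inhibitor), compound 1 `COc1ccc(Sc2ccc(NC3=NCCN3)cc2)cc1` gives 50.1 nM; 50.1 nM (2 entries) and 50.1 nM; 50.1 nM (2 entries) in two entries. In this assay compound 2 `CC(C)c1ccc(Sc2ccc(NC3=NCCN3)cc2)cc1` gives 251 nM and stands as the weaker of the two measured compounds; the gap to compound 1 lies beyond the usual scatter. A further entry for compound 2 in this assay is a limit of the assay and not a number.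

Compound 3 `O=C(O)c1ccc(Sc2ccc(NC3=NCCN3)cc2)cc1` is not yet measured. It differs from compound 2 by carboxy in place of isopropyl on an aromatic carbon. Going by the values given here, no step between measured compounds is recorded for this change, so its size can only be expected, not read off. Going by compound 1, where a group with a hydrogen-bond acceptor gave 50.1 nM; 50.1 nM (2 entries), a step toward stronger binding of moderate size is expected for compound 3, with wide uncertainty.

The expected step of a 2.1-fold lower number from compound 2 to compound 3 (0.32 log units; beyond the scatter) would place compound 3 at an estimated 120 nM in this assay, within a range of 25 nM to 600 nM.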

Compound 3, inhibition constant: < 10000 nM
Compound 3: only a limit was reported (the forecaster's own chance of this, stated with the estimate: 15%); the middle value is on the limit's open side.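

In this assay compound 3 gives < 10000 nM, which is a limit of the assay and not a number. Going by these compounds alone, no step from compound 2 to compound 3 can therefore be read. The compounds shown leave open how far carboxy in place of isopropyl on an aromatic carbon shifts the inhibition constant, and in which direction.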